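The compounds below may be only part of what the source reports. "The series", "measured", "known", "first", "only" and "open" are said of these compounds alone.

Compound 1 `Cc1cc(CN2C(=O)C(C3=NS(=O)(=O)c4c(CNS(C)(=O)=O)cccc43)=C(O)[C@@H]2C(C)(C)C)ccc1F`: 8.4 mL/min/kg
Compound 2 `Cc1cc(CN2C(=O)C(C3=NS(=O)(=O)c4c(CNS(N)(=O)=O)cccc43)=C(O)[C@@H]2C(C)(C)C)ccc1F`: 48 mL/min/kg

For the measured compounds named here, in an in vivo ADME assay on the whole organism for pharmacokinetics, with Rattus norvegicus as the target (a higher number here means faster removal of the compound, a lower number slower removal), compound 2 gives 48 mL/min/kg, the higher of the two numbers so far, so it is the faster-cleared of the pair. The next compound, compound 3 `Cc1cc(CN2C(=O)C(C3=NS(=O)(=O)c4c(CN(C)S(C)(=O)=O)cccc43)=C(O)[C@@H]2C(C)(C)C)ccc1F`, has not yet been measured. The structural change is methyl(methylsulfonyl)amino in place of sulfamoylamino on a saturated chain carbon bound to an aromatic carbon. In words, methyl(methylsulfonyl)amino stands in place of sulfamoylamino on a saturated chain carbon bound to an aromatic carbon.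

Going by the values given here, only one measured step bears on this change: amino in place of methyl on a sulfonyl sulfur gave a 5.7-fold higher number from compound 1 to compound 2 (0.76 log units; beyond the scatter). Compound 3 carries a methyl on the sulfonyl sulfur, as compound 1 does, so much of that step may be reversed. Among the compounds with values here, the other methyl in methyl(methylsulfonyl)amino has no measured step of its own, and this keeps the expectation loose. A clear drop in this assay is therefore expected, and the expected step is a 3.0-fold lower number from compound 2 to compound 3 (0.48 log units; beyond the scatter). For compound 3 the estimate is 16 mL/min/kg, with an expected range of 6 mL/min/kg to 40 mL/min/kg.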

Compound 3, clearance: 34.4 mL/min/kg
Estimate against measurement, compound 3: 2.2-fold (0.33 log units) below, and the stated range covers the measured number.
By their numbers in this assay, from the lowest: compound 1; then compounds 3 and 2 (each within the scatter of the next).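

In this assay, methyl in place of hydrogen on the sulfonamide nitrogen gives a 4.1-fold higher number from compound 1 to compound 3 (0.61 log units; beyond the scatter) and shows that the slow removal of compound 1 can be lost through a change at this nitrogen, not only through the change at the sulfonyl sulfur seen earlier. Replacing sulfamoylamino with methyl(methylsulfonyl)amino on the saturated chain carbon bound to an aromatic carbon gives a 1.4-fold lower number from compound 2 to compound 3 (0.14 log units; within the scatter) and so separates these two compounds by no more than ordinary scatter, even though the edits that link each to compound 1 sit at different atoms of the group. No measurement at hand explains why either edit has this effect.

The compounds shown leave open whether the effect at the nitrogen is particular to methyl or would also appear with a longer chain such as ethyl. They also leave open whether the sulfonyl group is needed at all, a question that an acetyl amide on the same saturated chain carbon would address through its number in this assay for comparison with these three compounds.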